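Dropping the Methoxy Group from Compound 3

The source may hold more compounds than are shown below. What is called first, only, known or untested is meant among the compounds shown, and "the series" means these compounds.

Three compounds share one core and were tested in a functional assay on HCT-116 cells (Homo sapiens) for cytotoxicity, read by MTT assay, with a stated time of 72 h; on this read-out lower numbers stand for stronger inhibition and higher numbers for weaker inhibition. Compound 1 `COc1cccc(/C=N/c2c(C)n(C)n(-c3ccccc3)c2=O)c1` gives 933000000 nM. Compound 2 `COc1ccc(/C=N/c2c(C)n(C)n(-c3ccccc3)c2=O)cc1OC` gives 575000000 nM. Compound 3 `COc1cc(/C=N/c2c(C)n(C)n(-c3ccccc3)c2=O)ccc1O` gives 468000000 nM, the lowest of the three numbers shown, yet both steps toward it, a 2.0-fold lower number from compound 1 to compound 3 (0.30 log units; within the scatter) and a 1.2-fold lower number from compound 2 to compound 3 (0.09 log units; within the scatter), stay within the scatter. Compound 4 `Cc1c(/N=C/c2ccc(O)cc2)c(=O)n(-c2ccccc2)n1C` differs from compound 3 by hydrogen in place of methoxy on an aromatic carbon. The closest comparison is a 1.6-fold lower number from compound 1 to compound 2 (0.21 log units; within the scatter), where a methoxy group enters and the number barely moves; taking one away is therefore expected to move the number little, if at all. For compound 4 the expected step is a 1.3-fold higher number from compound 3 to compound 4 (0.11 log units; within the scatter). The estimate for compound 4 is 600000000 nM, with a range from 300000000 nM to 1200000000 nM.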

Compound 4, half-maximal inhibitory concentration: 646000000 nM
Estimate against measurement, compound 4: 1.1-fold (0.03 log units) below; low and high end bracket the measured number.
By their numbers in this assay, from the lowest: compounds 3, 2, 4 and 1 (each within the scatter of the next).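

Taking the methoxy group away gives a 1.4-fold higher number from compound 3 to compound 4 (0.14 log units; within the scatter), so in this assay this position holds a methoxy group or a hydrogen with no difference that can be told from the scatter. The change of the whole aryl group is just as small, with a 1.4-fold lower number from compound 1 to compound 4 (0.16 log units; within the scatter). A methoxy group at this position now gives a similarly small step in two settings, one with a hydroxy group on the ring and one with a methoxy group:  the same change on two cores in this assay, a 1.6-fold lower number (0.21 log units; within the scatter) from compound 1 to compound 2 and a 1.4-fold lower number (0.14 log units; within the scatter) from compound 4 to compound 3, 1.2-fold (0.07 log units) apart, within the scatter of two such steps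

Every step shown stays within the scatter, so nothing yet shows what would move the number at this position. On these data alone, whether an amine, a carboxylic acid or a longer chain such as propoxy would do so remains open.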